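A 4-aminophenyl group replaces 1-methyl-1H-pyrazol-5-yl

The source may report more compounds than this note shows. Statements on the series, on what has been measured and on what is new or still open speak of the compounds shown alone.

In a functional assay on NCI-H1993 cells (Homo sapiens) for inhibition, read by CCK-8 assay, with a stated time of 72 h (on this read-out higher numbers stand for weaker inhibition and lower numbers for stronger inhibition), compound 2 `Cn1nccc1-c1cnc2ncn(Cc3ccc4ncccc4c3)c2n1` gives 7910 nM as the highest of three numbers, which means the weakest inhibition, and its gaps to both others lie beyond the scatter. Compound 1 `Cc1c(C(C)n2cnc3ncc(-c4cnn(CCO)c4)nc32)ccc2ncccc12` gives 726 nM and compound 3 `CC(c1cc2cccnc2cc1F)n1cnc2ncc(-c3ccc(C(N)=O)c(F)c3)nc21` gives 19.5 nM in this assay but each differs from compound 2 in more than one place. Compound 4 `Nc1ccc(-c2cnc3ncn(Cc4ccc5ncccc5c4)c3n2)cc1` keeps the core of compound 2 and carries 4-aminophenyl in place of 1-methyl-1H-pyrazol-5-yl on an aromatic carbon. For the measured compounds named here, no measured pair isolates this exchange, so any expectation remains loose. Compound 3 also carries a six-membered aromatic ring of carbon only and gives 19.5 nM as the lowest number, although compound 1 gives 726 nM with a five-membered aromatic ring and so offers no clean support. The expected change is a 6.6-fold lower number from compound 2 to compound 4 (0.82 log units; beyond the scatter) in this assay towards stronger inhibition and beyond the scatter. For compound 4 the estimated value is 1200 nM within an expected range of 200 nM to 6000 nM in this assay for now.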

Compound 4, half-maximal inhibitory concentration: 4950 nM
Estimate against measurement, compound 4: 4.1-fold (0.62 log units) below, within the range that was stated.
By their numbers in this assay, from the lowest: compound 3; then compound 1; then compounds 4 and 2 (each within the scatter of the next).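

In this assay the exchange of 1-methyl-1H-pyrazol-5-yl for 4-aminophenyl gives a 1.6-fold lower number from compound 2 to compound 4 (0.20 log units; within the scatter), and this is the only pair shown that isolates a change at this position. On this aromatic carbon, a six-membered aromatic ring of carbon only can therefore take the place of a five-membered aromatic ring with 2 hetero atoms without a difference that can be told from the scatter. Nothing measured here bears on why the two groups read alike.

The compounds shown leave open whether a carboxylic acid or a piperazine on the phenyl ring at this position would give a step beyond the scatter. They also leave open whether 4-aminophenyl would read the same way on the cores of compound 1 and compound 3.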